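This account rests on a few compounds, and the source may have more. Where it says the series, first, only, none or still open, it means among the compounds named here.

Measured compounds, with their values in an assay on MDA-MB-231 cells for displacement of a labelled ligand from C-X-C chemokine receptor type 4 (Homo sapiens), read by fluorescence and microscopy, with stated times of 10 min and 30 min; on this read-out higher numbers stand for an effect only at larger amounts of compound and lower numbers for an effect already at smaller amounts:

Compound 1 `O=C(NCc1ccc(CNS(=O)(=O)c2cccc(F)c2)cc1)c1cccnc1` gives 1000 nM.
Compound 2 `O=C(NCc1ccc(CNS(=O)(=O)c2ccccc2F)cc1)c1cccnc1` gives 100 nM.
Compound 3 `COc1ccccc1C(=O)NCc1ccc(CNS(=O)(=O)c2ccccc2F)cc1` gives 1 nM.

The three compounds share a core and differ at two ends of it. Compound 1 and compound 2 differ at one end only, (3-fluorophenyl in place of 2-fluorophenyl on a sulfonyl sulfur), and here the step is a 10-fold higher number from compound 2 to compound 1 (1.00 log units; beyond the scatter). Compound 2 and compound 3 differ at the other end, (2-methoxyphenyl in place of pyridin-3-yl on a carbonyl carbon), and this step is a 100-fold lower number from compound 2 to compound 3 (2.00 log units; beyond the scatter). Compound 3 therefore stands with the lowest number of the three; its steps to compound 2 and to compound 1 are both beyond the scatter.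

Compound 4 `COc1ccccc1C(=O)NCc1ccc(CNS(=O)(=O)c2cccc(F)c2)cc1` has not yet been measured in this assay. It differs from compound 3 in the same way that compound 1 differs from compound 2: 3-fluorophenyl in place of 2-fluorophenyl on a sulfonyl sulfur. The place of the change is described in the same words for both pairs, so this is the same change, carried out on the core of compound 3 instead of the core of compound 2; the two cores differ as stated above, with the change at the carbonyl carbon.

Among the compounds with values here, the only measured instance of this change, from compound 2 to compound 1, gives a 10-fold higher number from compound 2 to compound 1 (1.00 log units; beyond the scatter). Within the data shown here, because a 10-fold higher number from compound 2 to compound 1 (1.00 log units; beyond the scatter) is the sole guide, and it occurs on a core that differs from that of compound 3 at the carbonyl end, the step from compound 3 to compound 4 is expected to be of similar size, a 10-fold higher number from compound 3 to compound 4 (1.00 log units; beyond the scatter), with the scatter of the assay added on either side. Compound 4 is therefore estimated to give about 10 nM in this assay, expected to lie between 3 nM and 40 nM.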

Compound 4, effective concentration (reported as EC, without a stated level of effect): 1000 nM
For compound 4 the middle estimate is 100-fold (2.00 log units) below the measured one; measured number outside the range, above it.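

In this assay, 3-fluorophenyl in place of 2-fluorophenyl on the sulfonyl sulfur gives a 1000-fold higher number from compound 3 to compound 4 (3.00 log units; beyond the scatter), so the change keeps its direction on the core of compound 3 but not its size: the same change on two cores in this assay, a 10-fold higher number (1.00 log units; beyond the scatter) from compound 2 to compound 1 and a 1000-fold higher number (3.00 log units; beyond the scatter) from compound 3 to compound 4, 100-fold (2.00 log units) apart, beyond the scatter of two such steps. Read the other way, 2-methoxyphenyl in place of pyridin-3-yl on the carbonyl carbon gives no change at the digits printed from compound 1 to compound 4 (within the scatter), so the large step seen with 2-fluorophenyl on the sulfonyl sulfur does not appear with 3-fluorophenyl: the same change on two cores in this assay, a 100-fold lower number (2.00 log units; beyond the scatter) from compound 2 to compound 3 and no change at the digits printed (within the scatter) from compound 1 to compound 4, 100-fold (2.00 log units) apart, beyond the scatter of two such steps. These four compounds show that the two ends do not add up independently and that a step measured on one core is a poor guide to its size on the other, but they do not show why this is so, and each comparison rests on a single pair.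

The compounds shown leave open whether this dependence between the two ends extends to other groups, such as an unsubstituted phenyl or a chlorophenyl on the sulfonyl sulfur. On these data alone, it is also open whether an alkyl chain or an amine-bearing group on the carbonyl carbon would follow compound 3 or compound 4 in how it responds to the fluorophenyl change.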